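Chain lengthening on the diphenylpyridine acid series

The compounds below may be only part of what the source reports. "The series", "measured", "known", "first", "only" and "open" are said of these compounds alone.

Measured compounds in an assay on cell membranes from spleen (Cavia porcellus) for binding affinity to leukotriene B4 receptor 1 (Homo sapiens); a higher number here means a weaker inhibitor, a lower number a stronger inhibitor:
compound 1 `O=C(O)CCCOc1cc(-c2ccccc2)cc(-c2ccccc2)n1` gives 300 nM;
compound 2 `Cc1ccc(-c2cc(-c3ccccc3)cc(OCCCCCC(=O)O)n2)cc1` gives 300 nM;
compound 3 `CC(CCCCOc1cc(-c2ccccc2)cc(-c2ccccc2F)n1)C(=O)O` gives 4 nM.

Compound 1 stands level with compound 2 at the digits shown, the two together the highest numbers of the three; compound 3 sits far lower, beyond the scatter, and is the only strong inhibitor here.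

Compound 4 `O=C(O)CCCCCCOc1cc(-c2ccccc2)cc(-c2ccccc2)n1` is not yet measured. Relative to compound 1 it carries 3-carboxypropyl in place of carboxy on a saturated chain carbon, three bonds along the chain from an oxygen on an aromatic ring.

Among the measured compounds shown here, no measured pair isolates this step. Because compound 2 gives 300 nM, a step of a 1.5-fold lower number from compound 1 to compound 4 (0.18 log units; within the scatter) is expected, that is, no change beyond the scatter, though the low value of compound 3 leaves room for a larger drop. Compound 4 is estimated at 200 nM, expected between 50 nM and 1000 nM.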

Compound 4, half-maximal inhibitory concentration: 25 nM
Compound 4: middle estimate off by 8.0-fold (0.90 log units), on the high side; the measured number lies below the stated range.
By their numbers in this assay, from the lowest: compound 3; then compound 4; then compounds 1 and 2 (each within the scatter of the next).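

With the core held constant, 3-carboxypropyl in place of carboxy on a saturated chain carbon gives a 12-fold lower number from compound 1 to compound 4 (1.08 log units; beyond the scatter) in this assay and is beyond the scatter. Among the compounds shown here, this is the first pair to isolate chain length, and it shows that the longer acid chain alone gives a large gain in this assay. No measurement here accounts for the gain.

From the compounds shown here alone, whether the gain builds gradually through 4-carboxybutyl and 5-carboxypentyl or continues to a longer chain such as 7-carboxyheptyl stays open. So does the effect of adding a methyl group on the chain of compound 4.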